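The source may hold more compounds than are shown below. What is called first, only, known or untested is meant among the compounds shown, and "the series" means these compounds.

Compound 1 `COc1ccccc1Nc1nc(-c2cccc(F)c2)nc2ccc(F)cc12` reaches in a functional assay on MDA-MB-231 cells (Homo sapiens) for cytotoxicity, read by MTT assay, with a stated time of 48 h (a lower number here means a stronger inhibitor, a higher number a weaker inhibitor), only the limit of > 50000 nM.
Compound 2 `Fc1ccc(Nc2nc(-c3cccc(F)c3)nc3ccc(F)cc23)cc1` reaches in this assay only the limit of > 50000 nM.

Compound 2 therefore stands at the limit of this assay; no number for it is known, and the other value shown is a limit as well. Within the data shown here, the single measured step, a step that the two limits leave unreadable from compound 1 to compound 2, cannot be read for size or direction, because of the limit of > 50000 nM in this assay, at which 2 of the 2 values shown sit. Compound 3 `Fc1cccc(-c2nc(Nc3ccc(Cl)cc3)c3cc(F)ccc3n2)c1` differs from compound 2 by chloro in place of fluoro on an aromatic carbon. Among the measured compounds shown here, no measured step bears on this change in a readable way, and the one step that exists, from compound 1 to compound 2, gives no size to lean on. Nothing in the shown values separates compound 3 from the limit, so no step beyond the scatter is expected in either direction, and the most likely outcome for compound 3 is expected to be another limit. On that basis compound 3 is estimated at 60000 nM, with a range from 15000 nM to 250000 nM, which means an expected step that the limit leaves unreadable from compound 2 to compound 3.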

Compound 3, half-maximal inhibitory concentration: > 50000 nM
Compound 3: no number, only a limit; the forecaster's own chance of this, stated with the estimate: 85%; the middle value lies beyond the limit too.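

In this assay compound 3 gives only a limit, > 50000 nM. No step among compound 1, compound 2 and compound 3 can be read for size or direction, because all three share one limit: the limit of > 50000 nM in this assay, at which 3 of the 3 values shown sit.

The compounds shown leave open whether 2-methoxyphenyl, 4-fluorophenyl or 4-chlorophenyl on the shared core makes any difference in this assay.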